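Isobutyl to isopropyl on the double-bonded nitrogen

The source may report more compounds than this note shows. Statements on the series, on what has been measured and on what is new or still open speak of the compounds shown alone.

Compound 1, `C/C(=N\CC(C)C)c1c(O)c2ccccc2oc1=O`, is the reference point of the series. In an assay on isolated protein for inhibition of myosin-2 (Bos taurus), read by spectrophotometry, with a stated time of 24 min (a higher number here means a weaker inhibitor, a lower number a stronger inhibitor), compound 1 gives 34000 nM, and this is the only number shown for the series. Compound 2, `CCC/C(=N\Cc1ccccc1)c1c(O)c2ccccc2oc1=O`, reports only a limit in this assay, >= 100000 nM, and not a number. The limit is recorded as the limit of >= 100000 nM in this assay, at which 1 of the 2 values shown sits.

Compound 3, `C/C(=N\C(C)C)c1c(O)c2ccccc2oc1=O`, is not yet measured. It differs from compound 1 in a single place: isopropyl in place of isobutyl on a double-bonded nitrogen. Both groups are branched alkyls with no ring, no hydrogen-bond donors and no hydrogen-bond acceptors, so the exchange is a modest one.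

Among the measured compounds shown here, no step between measured compounds is available to set a scale for this kind of change. In this assay the expected movement from compound 1 to compound 3 is small, within the usual scatter, with no firm direction. The step of a 1.3-fold higher number from compound 1 to compound 3 (0.12 log units; within the scatter) is the expected outcome. Compound 3 is therefore estimated at 45000 nM in this assay, with a range from 15000 nM to 150000 nM, and the chance that only a limit is returned is real given how near compound 1 already sits to the weak end.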

Compound 3, half-maximal inhibitory concentration: >= 100000 nM
Compound 3 ended at the assay's limit (the forecaster's own chance of this, stated with the estimate: 25%); at least 2.2-fold (0.34 log units) between middle value and limit.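

Among the compounds shown here, changing isobutyl to isopropyl on the double-bonded nitrogen gives the first readable step: in this assay the change is an at least 2.9-fold higher number from compound 1 to compound 3 (0.46 log units; beyond the scatter). For compound 3 the value >= 100000 nM is a limit and not a number. An exchange between two branched alkyls with no ring is therefore enough at this place to lose the measurable reading, and compound 1 remains the only compound in the series with a number: the limit of >= 100000 nM in this assay, at which 2 of the 3 values shown sit.

As far as these compounds go, how far past the limit compound 3 lies stays unknown, so the step can be read only as a minimum and its true size remains open. Also open, from the compounds shown here alone, is whether a longer chain such as pentyl, a cyclohexyl ring or a chain carrying an amine on the double-bonded nitrogen would return a number in this assay, and whether any such group would give a stronger inhibitor than compound 1.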